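Swapping a Small Ring for a Bromophenyl Ring on the Thioether

This account rests on a few compounds, and the source may have more. Where it says the series, first, only, none or still open, it means among the compounds named here.

Measured compounds:
Compound 1, `Cc1cc(N2CC[C@@H](C)[C@@H](N(C)c3ncnc4[nH]ccc34)C2)n2nc(SCC3CC3)nc2n1`: 9540 nM
Compound 2, `Cc1cc(N2CC[C@@H](C)[C@@H](N(C)c3ncnc4[nH]ccc34)C2)n2nc(SCCc3ccccc3)nc2n1`: 6190 nM

Both compounds share the same core and differ only in the group carried on the saturated chain carbon bound to the sulfur. In a functional assay on MGC-803 cells (Homo sapiens) for inhibition, read by MTT assay, with a stated time of 72 h (a lower number here means a stronger inhibitor, a higher number a weaker inhibitor), compound 1 gives 9540 nM, the highest of the two numbers, while compound 2 gives 6190 nM. Among the compounds with values here, the one measured step, a 1.5-fold lower number from compound 1 to compound 2 (0.19 log units; within the scatter), shows that a benzyl in place of cyclopropyl at this spot leaves the result within the scatter.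

The unmeasured compound 3, `Cc1cc(N2CC[C@@H](C)[C@@H](N(C)c3ncnc4[nH]ccc34)C2)n2nc(SCc3ccc(Br)cc3)nc2n1`, carries the change (4-bromophenyl in place of cyclopropyl on a saturated chain carbon bound to a sulfur). The step from compound 1 to compound 2 is the only one that bears on it, and it was small. An aromatic ring in the same place is therefore expected to give at most a modest move toward a lower number in this assay, if any beyond the scatter. For compound 3 the expected step is a 1.7-fold lower number from compound 1 to compound 3 (0.24 log units; within the scatter). Compound 3 is thus estimated at 5500 nM, with a range from 2000 nM to 15000 nM.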

Compound 3, half-maximal inhibitory concentration: 4020 nM
The estimate for compound 3 lay 1.4-fold (0.14 log units) above the measured number; the measured number falls inside the stated range.
By their numbers in this assay, from the lowest: compounds 3, 2 and 1 (each within the scatter of the next, the first and the last beyond it).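

In this assay, within the data shown here, 4-bromophenyl gives the first change on this saturated chain carbon bound to a sulfur that clears the scatter (a 2.4-fold lower number from compound 1 to compound 3 (0.38 log units; beyond the scatter)), so replacing cyclopropyl with this aromatic ring can shift the number, though only modestly. Replacing benzyl with 4-bromophenyl does not separate the two groups (a 1.5-fold lower number from compound 2 to compound 3 (0.19 log units; within the scatter)), so compound 2 and compound 3 cannot be ranked in this assay. No measurement here explains the shift seen with 4-bromophenyl.

From the compounds shown here alone, it remains open how much of that shift belongs to the bromine, since a plain phenyl, a 4-chlorophenyl or a 4-methoxyphenyl on the same carbon could settle that comparison. Also open, going by these compounds, is how a group carrying an amine or a carboxylic acid would behave at this spot.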